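Methoxy in Place of Methyl on a Biaryl Agonist

The compounds below may be only part of what the source reports. "The series", "measured", "known", "first", "only" and "open" are said of these compounds alone.

Compound 1 `CO/N=C1\CC(CC(=O)O)c2ccc(OCc3cccc(-c4c(C)cc(OC)cc4C)c3)cc21` reaches only the limit of > 1000 nM in a functional assay on CHO cells for agonist activity at Free fatty acid receptor 1 (Homo sapiens), read by FLIPR and calcium flux (on this read-out lower numbers stand for an effect already at smaller amounts and higher numbers for an effect only at larger amounts of compound), so no number is known for it. Going by the values given here, compound 2 `Cc1ccccc1-c1cccc(COc2ccc(S(=O)(=O)CC(=O)O)cc2)c1` gives 46.8 nM in this assay; this is the only number measured here. The one further result, that of compound 1, is a limit (the limit of > 1000 nM in this assay, at which 1 of the 2 values shown sits). Compound 3 `COc1ccccc1-c1cccc(COc2ccc(S(=O)(=O)CC(=O)O)cc2)c1` differs from compound 2 in one place: methoxy in place of methyl on an aromatic carbon. No measured step of this kind is available among these compounds, so the size of its effect cannot be read from the data. Compound 3 is therefore expected to stay close to compound 2, with a step of a 1.1-fold higher number from compound 2 to compound 3 (0.03 log units; within the scatter) that lies within the usual scatter of this assay. The estimate for compound 3 in this assay is 50 nM, with a range from 15 nM to 200 nM.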

Compound 3, half-maximal effective concentration: 195 nM
The estimate for compound 3 lay 3.9-fold (0.59 log units) below the measured number; measured number inside the range.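

Methoxy in place of methyl, on the aromatic carbon ortho to a large group, gives a 4.2-fold higher number from compound 2 to compound 3 (0.62 log units; beyond the scatter) in this assay, the first measured step among these compounds. The change from 2-methylphenyl to 2-methoxyphenyl is therefore not neutral at this position: one more heavy atom, an oxygen that counts as a hydrogen-bond acceptor, goes with a higher number, although compound 3 still gives a measured value of 195 nM. Nothing in the data shown accounts for this step.

Going by these compounds, it remains open how a chlorine, an ethyl or a hydroxyl on the same carbon would compare with the methyl of compound 2 and the methoxy of compound 3. On these data alone, it also remains open whether the same change would give a similar step on another core.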